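This account rests on a few compounds, and the source may have more. Where it says the series, first, only, none or still open, it means among the compounds named here.

Measured in an in vitro ADME assay on microsomes from liver (Homo sapiens) for metabolic stability; a lower number here means slower removal, a higher number faster removal of the compound:
- compound 1 `CC(C)NC(=O)[C@H]1CC[C@@H](n2/c(=N/C(=O)c3cc(F)cc(Cl)c3)[nH]c3ccc(CN4CCC(C(C)(C)O)CC4)cc32)CC1`: 83 mL.min-1.g-1
- compound 2 `CC(C)NC(=O)[C@H]1CC[C@@H](n2/c(=N/C(=O)c3ccc(F)c(F)c3)[nH]c3ccc(CN4CCC(C(C)(C)O)CC4)cc32)CC1`: 60 mL.min-1.g-1

Only these two values are available, and they lie within the scatter of each other, so compound 2 has no clear rank in the series. The next compound is compound 3 `CC(C)NC(=O)[C@H]1CC[C@@H](n2/c(=N/C(=O)c3ccncc3)[nH]c3ccc(CN4CCC(C(C)(C)O)CC4)cc32)CC1`, with pyridin-4-yl in place of 3,4-difluorophenyl on a carbonyl carbon. In words, this is pyridin-4-yl in place of 3,4-difluorophenyl on a carbonyl carbon.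

Among the measured compounds shown here, one measured step bears on this place: a 1.4-fold lower number from compound 1 to compound 2 (0.14 log units; within the scatter). For the measured compounds named here, that step exchanges one halogen-bearing phenyl group for another, and no measured step brings in a ring with a hetero atom, so it is only a weak guide. No change beyond the scatter is therefore expected. The expected step is a 1.4-fold lower number from compound 2 to compound 3 (0.15 log units; within the scatter).

For compound 3, the estimate in this assay is 42 mL.min-1.g-1, with an expected range of 18 mL.min-1.g-1 to 90 mL.min-1.g-1.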

Compound 3, intrinsic clearance in microsomes: 57 mL.min-1.g-1
The estimate for compound 3 lay 1.4-fold (0.13 log units) below the measured number; the measured number falls inside the stated range.
By their numbers in this assay, from the lowest: compounds 3, 2 and 1 (each within the scatter of the next).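

In this assay, pyridin-4-yl in place of 3,4-difluorophenyl on a carbonyl carbon gives a 1.1-fold lower number from compound 2 to compound 3 (0.02 log units; within the scatter) and, set against the other halogen-bearing phenyl group, pyridin-4-yl in place of 3-chloro-5-fluorophenyl gives a 1.5-fold lower number from compound 1 to compound 3 (0.16 log units; within the scatter). The earlier pair held only halogen-bearing phenyl groups, whereas compound 3 shows that a six-membered aromatic ring with 1 hetero atom and no halogen also stands within the scatter of both, so this read-out does not separate the three groups at this place. Nothing available explains this lack of separation.

Still open, on these data alone, is whether any group on this carbonyl carbon gives a step beyond the scatter, for instance a saturated cyclohexyl ring or a phenyl ring carrying a carboxylic acid or an amine. Also open, as far as these compounds go, is whether pyridin-4-yl would give the same result with a different group on the amide at the other end of the molecule.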